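The source may hold more compounds than are shown below. What is called first, only, known or untested is meant among the compounds shown, and "the series" means these compounds.

Compound 1 `O=C(Nc1ccc(Oc2ccc(-c3nccs3)cc2)cc1)Nc1ccc(F)c(C(F)(F)F)c1` is one of three ureas sharing a core that differ only in the aryl group on one urea nitrogen. In a functional assay on MDA-MB-231 cells (Homo sapiens) for inhibition, read by MTT assay and WST assay, with a stated time of 72 h, tested at 10 uM (on this read-out higher numbers stand for more inhibition of growth at the one concentration tested and lower numbers for less inhibition of growth), compound 1 gives 71.8%, the second highest of the three numbers. Compound 2 `O=C(Nc1ccc(Oc2ccc(-c3nccs3)cc2)cc1)Nc1cc(Br)cc(C(F)(F)F)c1` gives 72.8%, and the step of a number 1 percentage points higher from compound 1 to compound 2 (within the scatter) lies within the scatter. Compound 3 `O=C(Nc1ccc(Oc2ccc(-c3nccs3)cc2)cc1)Nc1ccc(F)c(Cl)c1` gives 43.9%, and the step of a number 27.9 percentage points lower from compound 1 to compound 3 (beyond the scatter) is beyond it, as is a number 28.9 percentage points lower from compound 2 to compound 3 (beyond the scatter).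

Compound 4 `O=C(Nc1ccc(Oc2ccc(-c3ncc[nH]3)cc2)cc1)Nc1ccc(F)c(C(F)(F)F)c1` changes the other end of the molecule: 1H-imidazol-2-yl in place of 1,3-thiazol-2-yl on an aromatic carbon. Going by the values given here, none of the three measured steps touches this end of the core, so no measured step bears directly on the change; all three concern the aryl urea end, and the only sizeable ones, a number 27.9 percentage points lower from compound 1 to compound 3 (beyond the scatter) and a number 28.9 percentage points lower from compound 2 to compound 3 (beyond the scatter), involve replacing trifluoromethyl. Without a comparable example, a step of a number 6.8 percentage points lower from compound 1 to compound 4 (within the scatter) that stays within the scatter is expected, though the range is wide. Compound 4 is therefore estimated at 65%, between 40% and 85%.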

Compound 4, percent growth inhibition at one concentration: 26.6%
Compound 4: the middle estimate sits 38.4 percentage points above what was measured, outside the stated range (below it).
By their numbers in this assay, from the lowest: compound 4; then compound 3; then compounds 1 and 2 (each within the scatter of the next).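

In this assay, going by these compounds alone, the earlier steps all concerned the aryl group on the urea, and this is the first to show that the other end of the molecule matters too: a number 45.2 percentage points lower from compound 1 to compound 4 (beyond the scatter). The swap keeps a five-membered aromatic ring with the same number of heavy atoms at the same place, para to a large group, so a change that leaves ring size untouched is still far from silent here. The 1H-imidazol-2-yl group replaces the sulfur with nitrogen and carries a hydrogen-bond donor that the 1,3-thiazol-2-yl group lacks, but nothing available says what lies behind the drop.

Still open, on these data alone, is which of those two differences counts, a question that 1,3-oxazol-2-yl or 1-methyl-1H-imidazol-2-yl at this position could help to answer. Also open, as far as these compounds go, is whether the same swap has a similar effect with the aryl groups of compound 2 and compound 3.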